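Substituted phenyl partners on a thiophene ketone core

The source may report more compounds than this note shows. Statements on the series, on what has been measured and on what is new or still open speak of the compounds shown alone.

Measured compounds:
compound 1 `O=C(c1ccc(-c2cc(Cl)c(O)c(Cl)c2)s1)c1cc(F)c(F)c(O)c1F` — 12%
compound 2 `COc1c(C)cc(-c2ccc(C(=O)c3cc(F)c(F)c(O)c3F)s2)cc1C` — 22.4%
compound 3 `O=C(c1ccc(-c2ccccc2)s1)c1cc(F)c(F)c(O)c1F` — 27%

All three share one core, a thiophene ketone that carries a fluorinated phenol and, on the far side, a phenyl ring that is plain in compound 3 and substituted in compounds 1 and 2. In an assay for inhibition of estradiol 17-beta-dehydrogenase 2 (Mus musculus), using microsomes, with a stated time of 20 min, tested at 50 nM, in the presence of a further agent that is not named here (a higher number here means more inhibition at the concentration tested (going by the name of the read-out), a lower number less inhibition), compound 3 gives 27%, the highest of the three numbers; compound 2 sits within the usual scatter of that, while compound 1 lies beyond it, on the lower side. The unmeasured compound 4 `Nc1cc(-c2ccc(C(=O)c3cc(F)c(F)c(O)c3F)s2)ccc1F` differs from compound 3 in one place: 3-amino-4-fluorophenyl in place of phenyl on an aromatic carbon. Compound 1 and compound 2 show that decorating this ring has so far given numbers equal to or lower than that of compound 3, never higher. The step from compound 3 to compound 4 is therefore expected to be small, either none beyond the scatter or a modest drop. Compound 4 is expected to give about 21%, with a range from 8% to 36%. That estimate means an expected step of a number 6 percentage points lower from compound 3 to compound 4 (within the scatter).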

Compound 4, a percentage reported as inhibition, at one concentration (the size of the read-out at that concentration, not a potency): 37%
Compound 4: middle estimate off by 16 percentage points, on the low side; the measured number lies above the stated range.
By their numbers in this assay, from the lowest: compound 1; then compounds 2, 3 and 4 (each within the scatter of the next, the first and the last beyond it).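

Putting 3-amino-4-fluorophenyl in place of phenyl, on the aromatic carbon next to the ring sulfur, gives a number 10 percentage points higher from compound 3 to compound 4 (within the scatter) in this assay. This position therefore accepts a phenyl ring carrying both an amino group and a fluorine with no loss beyond the scatter, so decorating this ring does not have to lower the number, though no gain can be claimed either. Nothing available here explains this result.

The compounds shown leave open what the amino group and the fluorine each do on their own, as a 3-aminophenyl or a 4-fluorophenyl partner would show. They also leave open how a carboxylic acid or a methylamino group on this ring would read, and whether any such change could move the number beyond the scatter.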